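Ethoxy to allyloxy: an expected modest gain in cytotoxicity

A few compounds are considered here, and "the series" means these few. Any claim that something is new, unique, unknown or untested is made for them only; others in the source may bear on it.

Compound 3 `CCOc1ccc2c(NCCCN(C)C)ccnc2c1` carries an ethoxy group on its aromatic ring and a three-carbon chain to the basic amine. In a functional assay on BGC-823 cells (Homo sapiens) for cytotoxicity, read by MTT assay, with a stated time of 48 h (a lower number here means a stronger inhibitor, a higher number a weaker inhibitor), compound 3 gives 9810 nM, the highest number among the three measured compounds. Compound 2 `CN(C)CCCNc1ccnc2cc(OCc3ccc(F)cc3)ccc12`, which bears a 4-fluorobenzyloxy group at the same place, gives 490 nM in this assay, and compound 1 `C=CCOc1ccc2c(NCCN(C)C)ccnc2c1`, which has the allyloxy group but a shorter chain to the amine, gives 1360 nM.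

Compound 4 `C=CCOc1ccc2c(NCCCN(C)C)ccnc2c1` is compound 3 with a single change: vinyl in place of methyl on a saturated chain carbon bound to an oxygen on an aromatic ring. For the measured compounds named here, the one measured step at this place is a 20-fold higher number from compound 2 to compound 3 (1.30 log units; beyond the scatter), where a much larger group was exchanged. Compound 1 and compound 3 differ in two places, so their values are only suggestive, yet compound 1 with its allyloxy group stands well below compound 3. The step to compound 4 adds far less than the group that was lost between compound 2 and compound 3, so a smaller move, downward, is expected in this assay.

Compound 4 is therefore estimated to give 2800 nM, with a range from 900 nM to 8000 nM. That estimate corresponds to an expected 3.5-fold lower number from compound 3 to compound 4 (0.54 log units; beyond the scatter).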

Compound 4, half-maximal inhibitory concentration: 6680 nM
Compound 4: middle estimate off by 2.4-fold (0.38 log units), on the low side, and the stated range covers the measured number.
By their numbers in this assay, from the lowest: compound 2; then compound 1; then compounds 4 and 3 (each within the scatter of the next).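

In this assay, the exchange of ethoxy for allyloxy does not separate the two compounds, with a 1.5-fold lower number from compound 3 to compound 4 (0.17 log units; within the scatter) as the step, so vinyl in place of methyl at this place leaves the number where it stood. With the allyloxy compound as the reference, the step to the 4-fluorobenzyloxy compound is still large, as a 14-fold higher number from compound 2 to compound 4 (1.13 log units; beyond the scatter) shows, so neither of the two small groups comes near the 4-fluorophenyl-bearing group on a saturated chain carbon bound to an oxygen on an aromatic ring. For the compounds shown here, the allyloxy group held constant also gives the first single-change reading of the chain to the amine, where a 4.9-fold higher number from compound 1 to compound 4 (0.69 log units; beyond the scatter) is a modest step beyond the scatter, and the lower number of compound 1 therefore goes with its shorter chain and not with the allyloxy group.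

The compounds shown leave open whether a plain benzyloxy group, without the fluorine, would keep the low number of compound 2, and whether the shorter chain would lower the number again when paired with 4-fluorobenzyloxy. Nothing at hand explains why these steps differ so much in size.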